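A few compounds are considered here, and "the series" means these few. Any claim that something is new, unique, unknown or untested is made for them only; others in the source may bear on it.

Working notes on the series. Three compounds have numbers in a functional assay on CCRF-CEM cells (Homo sapiens) for inhibition, read by MTT assay, with a stated time of 2 days, tested at 10 uM; on this read-out higher numbers stand for more inhibition at the one concentration tested (going by the name of the read-out) and lower numbers for less inhibition. Compound 1 `O=C(OCCCc1ccccc1)c1cc(-n2cc(-c3cccc(O)c3)nn2)ccc1O` gives 9%. Compound 2 `COC(=O)c1cc(-n2cc(-c3cc(O)ccc3O)nn2)ccc1O` gives 52%. Compound 3 `COC(=O)c1cc(-n2cc(-c3ccc(OC)cc3)nn2)ccc1O` gives 16%. Among the compounds with values here, on these three numbers compound 3 stands second highest; compound 1 is within the scatter of it, while compound 2 lies beyond the scatter above it, the one measured step being a number 36 percentage points lower from compound 2 to compound 3 (beyond the scatter).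

The next compound is compound 4 `COC(=O)c1cc(-n2cc(-c3cccc(O)c3)nn2)ccc1O`, which differs from compound 3 in one place: 3-hydroxyphenyl in place of 4-methoxyphenyl on an aromatic carbon. Within the data shown here, no measured step covers exactly this exchange. The step from compound 2 to compound 3 bears on it only in part, since it also swapped a hydroxyphenyl for a methoxyphenyl, and it was large. Compound 1, which carries the same 3-hydroxyphenyl but a different ester, sits at 9%, within the scatter of compound 3. Taken together, the expected step of a number 4 percentage points higher from compound 3 to compound 4 (within the scatter) in this assay is small, not beyond the scatter in either direction. Compound 4 is therefore estimated at 20%, with a range from 5% to 40%.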

Compound 4, a percentage reported as inhibition, at one concentration (the size of the read-out at that concentration, not a potency): 5%
Estimate against measurement, compound 4: 15 percentage points above, and the stated range covers the measured number.
By their numbers in this assay, from the lowest: compounds 4, 1 and 3 (each within the scatter of the next, the first and the last beyond it); then compound 2.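

In this assay the removal of one hydroxy from the aryl group gives a number 47 percentage points lower from compound 2 to compound 4 (beyond the scatter), so the 3-hydroxyphenyl does not carry the number seen with the 2,5-dihydroxyphenyl, and a single hydroxy is not enough in this pair. The exchange against the 4-methoxyphenyl gives a number 11 percentage points lower from compound 3 to compound 4 (beyond the scatter) and adds a modest step in favour of the methoxy compound, while the ester chain, read with the 3-hydroxyphenyl held fixed, gives a number 4 percentage points lower from compound 1 to compound 4 (within the scatter) and so makes no difference beyond the scatter here. Nothing at hand gives a reason for these steps.

Going by these compounds, whether the second hydroxy of compound 2 counts through its presence or through its place stays open. So does whether an amine or a carboxylic acid on this aryl group could take the place of that hydroxy.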